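The source may report more compounds than this note shows. Statements on the series, on what has been measured and on what is new or still open speak of the compounds shown alone.

Working notes on the amide aryl group of the shared core. Compound 1 `COc1cc(NC(=O)c2cncc(N3CC4CC(C3)N4)c2)cc(OC)c1` carries a 3,5-dimethoxyphenyl group and in an assay on membranes from Cerebral cortex for displacement of a labelled ligand from Neuronal acetylcholine receptor; alpha4/beta2 (Rattus norvegicus) (on this read-out lower numbers stand for stronger inhibition and higher numbers for weaker inhibition), gives 0.985 nM. Compound 2 `O=C(Nc1ccc(I)cc1)c1cncc(N2CC3CC(C2)N3)c1` gives 0.366 nM in this assay, and compound 3 `O=C(Nc1ccc(F)cc1F)c1cncc(N2CC3CC(C2)N3)c1` gives 0.051 nM. Among the three measured values compound 3 stands lowest; its nearest neighbour is compound 2, from which it is separated by a 7.2-fold lower number from compound 2 to compound 3 (0.86 log units; beyond the scatter), while compound 1 lies furthest away, well beyond the scatter on the values shown.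

Compound 4 `COc1cccc(NC(=O)c2cncc(N3CC4CC(C3)N4)c2)c1` is the next point: 3-methoxyphenyl in place of 2,4-difluorophenyl on an amide-type nitrogen. Within the data shown here, only one measured step touches this aryl group, a 7.2-fold lower number from compound 2 to compound 3 (0.86 log units; beyond the scatter), and it shows that swapping the ring can shift the number clearly beyond the scatter. Among the measured compounds shown here, a methoxy-bearing ring is otherwise seen only in compound 1, whose value sits well above that of compound 3, so a move back upward in this assay is expected, of a size comparable to the steps already seen. Compound 4 is therefore estimated at 0.4 nM, with a range from 0.1 nM to 1.5 nM. The expected step is a 7.8-fold higher number from compound 3 to compound 4 (0.89 log units; beyond the scatter).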

Compound 4, inhibition constant: 0.56 nM
Compound 4: the middle estimate sits 1.4-fold (0.15 log units) below what was measured; measured number inside the range.
By their numbers in this assay, from the lowest: compound 3; then compounds 2, 4 and 1 (each within the scatter of the next, the first and the last beyond it).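

Replacing 2,4-difluorophenyl with 3-methoxyphenyl on the amide-type nitrogen gives an 11-fold higher number from compound 3 to compound 4 (1.04 log units; beyond the scatter) in this assay, the largest step yet seen at this place. The other two new steps stay within the scatter, a 1.5-fold higher number from compound 2 to compound 4 (0.18 log units; within the scatter) and a 1.8-fold lower number from compound 1 to compound 4 (0.25 log units; within the scatter), so compound 4 cannot be told apart from compound 2 or compound 1, and hydrogen in place of one methoxy does not register on this read-out. Among the compounds shown, only compound 3 stands clear of the rest, and no supporting measurement accounts for this.

From the compounds shown here alone, it remains open whether the low number of compound 3 requires both fluorines or would persist with a monofluorophenyl group. Unsubstituted phenyl, a chlorophenyl group and an aminophenyl group would also test how far it is specific to 2,4-difluorophenyl.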